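Bromo in Place of Methoxycarbonyl: Little Change Expected

The source may hold more compounds than are shown below. What is called first, only, known or untested is meant among the compounds shown, and "the series" means these compounds.

Three measured compounds share one core and differ only in the group carried on the side chain. In a functional assay on MCF7 cells (Homo sapiens) for antiproliferative activity, read by MTT assay, with a stated time of 48 h (a higher number here means a weaker inhibitor, a lower number a stronger inhibitor), compound 1 `O=c1cc(-n2cc(CSc3ccccc3)nn2)c2cc(Br)ccc2o1` gives 36800 nM. Compound 2 `O=c1cc(-n2cc(COc3cccnc3)nn2)c2cc(Br)ccc2o1` gives 39800 nM in this assay. Compound 3 `COC(=O)c1ccccc1OCc1cn(-c2cc(=O)oc3ccc(Br)cc23)nn1` gives 34100 nM in this assay, the lowest of the three numbers, though its gaps to compound 1 and to compound 2 both lie within the scatter. Going by the values given here, the only single-change step, a 1.1-fold higher number from compound 1 to compound 2 (0.03 log units; within the scatter), altered the group at the end of the chain and stayed within the scatter. Compound 4 `O=c1cc(-n2cc(COc3ccccc3Br)nn2)c2cc(Br)ccc2o1` differs from compound 3 by bromo in place of methoxycarbonyl on an aromatic carbon. Compound 4 is therefore expected to show a 1.1-fold higher number from compound 3 to compound 4 (0.02 log units; within the scatter). Compound 4 is estimated at 36000 nM, within 18000 nM to 72000 nM.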

Compound 4, half-maximal inhibitory concentration: 28900 nM
Estimate against measurement, compound 4: 1.2-fold (0.10 log units) above, and the stated range covers the measured number.
By their numbers in this assay, from the lowest: compounds 4, 3, 1 and 2 (each within the scatter of the next).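

In this assay, bromo in place of methoxycarbonyl on this aromatic carbon, ortho to a large group, gives a 1.2-fold lower number from compound 3 to compound 4 (0.07 log units; within the scatter), so a one-atom group and a four-atom ester read the same here. The other two steps, a 1.4-fold lower number from compound 2 to compound 4 (0.14 log units; within the scatter) and a 1.3-fold lower number from compound 1 to compound 4 (0.10 log units; within the scatter), show that the new 2-bromophenoxy end group also reads the same as the two earlier end groups. Nothing measured here bears on why these numbers stay so close. Going by these compounds, whether an amine or a carboxylic acid on this aromatic carbon would give a step beyond the scatter remains open. So does the outcome of a longer chain leading to this ring.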